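Ethylamino to methylamino on the shared core

A few compounds are considered here, and "the series" means these few. Any claim that something is new, unique, unknown or untested is made for them only; others in the source may bear on it.

For the measured compounds named here, compound 1 `CCNc1nccc2c1ncn2C1O[C@H](CO)[C@@H](O)[C@H]1O` holds the only number so far in a functional assay on EL4 cells (Mus musculus) for inhibition, tested at 100 uM; a higher number here means more inhibition at the concentration tested (going by the name of the read-out), a lower number less inhibition; there compound 1 gives 8%. Compound 2 `[O-][n+]1ccc2c(c1)ncn2C1O[C@H](CO)[C@@H](O)[C@H]1O` sits at a limit of the assay: in this assay compound 2 gives < 5%, which is a limit and not a number (the limit of < 5% in this assay, at which 1 of the 2 values shown sits). Compound 3 `CNc1nccc2c1ncn2C1O[C@H](CO)[C@@H](O)[C@H]1O` is not yet measured in this assay. It differs from compound 1 by hydrogen in place of methyl on a saturated chain carbon bound to a nitrogen on an aromatic ring. Going by the values given here, no measured step of this kind exists, so the expected step, a number 1 percentage points lower from compound 1 to compound 3 (within the scatter), is none beyond the scatter, in no preferred direction. For compound 3 the expected value in this assay is 7%, within 0% to 17%.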

Compound 3, a percentage reported as inhibition, at one concentration (the size of the read-out at that concentration, not a potency): 11%
For compound 3 the middle estimate is 4 percentage points below the measured one; the range from low to high includes it.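

In this assay, for the compounds shown here, ethylamino to methylamino on the shared core gives a number 3 percentage points higher from compound 1 to compound 3 (within the scatter) as the first measured step at this position. On this step, the methyl on the saturated chain carbon can leave without a difference beyond the scatter. No available evidence bears on a cause for this step.

Open, going by these compounds, is whether an unsubstituted amino group or a longer chain such as propyl on that nitrogen would give a step beyond the scatter. Also open, on these data alone, is whether a cyclopropyl group there would do so.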